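Aryl swap on the shared core: compound 3 expected

A few compounds are considered here, and "the series" means these few. Any claim that something is new, unique, unknown or untested is made for them only; others in the source may bear on it.

In a functional assay on MCF7 cells (Homo sapiens) for inhibition, read by sulforhodamine B assay, with a stated time of 48 h, tested at 10 uM (a lower number here means less inhibition, a higher number more inhibition at the concentration tested (going by the name of the read-out)), compound 2 `CC(=O)c1ccc(-c2cn3ccnc3c(-c3ccc4ncn(C5CCCCC5)c4c3)n2)cc1` gives 12%, and compound 1 `c1ccc2c(-c3cn4ccnc4c(-c4ccc5ncn(C6CCCCC6)c5c4)n3)cccc2c1` gives 13%; the two numbers sit within the scatter of each other, so neither stands apart. Compound 3 `Fc1ccccc1-c1cn2ccnc2c(-c2ccc3ncn(C4CCCCC4)c3c2)n1` differs from compound 2 by 2-fluorophenyl in place of 4-acetylphenyl on an aromatic carbon. For the measured compounds named here, no measured step covers this change directly; the only step recorded, a number 1 percentage points lower from compound 1 to compound 2 (within the scatter), also exchanged one aryl group for another and stayed within the scatter. Accordingly no step beyond the scatter is expected for compound 3 in this assay. Compound 3 is estimated at 12%, with a range of 2% to 26%, an expected step of no change at the digits printed from compound 2 to compound 3 (within the scatter).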

Compound 3, a percentage reported as inhibition, at one concentration (the size of the read-out at that concentration, not a potency): 11.2%
Estimate against measurement, compound 3: 0.8 percentage points above; the measured number falls inside the stated range.
By their numbers in this assay, from the lowest: compounds 3, 2 and 1 (each within the scatter of the next).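

In this assay, 2-fluorophenyl in place of 4-acetylphenyl removes the carbonyl and the only counted hydrogen-bond acceptor of the leaving group, yet the step stays small (a number 0.8 percentage points lower from compound 2 to compound 3 (within the scatter)). Against naphthalen-1-yl, the step from the same position is also small (a number 1.8 percentage points lower from compound 1 to compound 3 (within the scatter)), so three differing aryl groups now sit within the scatter of one another. No measurement here accounts for this result.

Still open, from the compounds shown here alone, is whether a carboxylic acid or an amine on this aryl ring would separate from these compounds. A saturated ring such as morpholine at this position also remains untested by the compounds shown.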